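Swapping methyl for phenyl on a ring nitrogen

The source may hold more compounds than are shown below. What is called first, only, known or untested is meant among the compounds shown, and "the series" means these compounds.

Measured so far:
compound 1, `CN1CC2=C(N=C(S)NC2c2cccs2)/C(=C/c2cccs2)C1`, 75000 nM
compound 2, `COc1ccc(/C=C2\CN(C)CC3=C2N=C(S)NC3c2ccc(OC)cc2)cc1`, 5900 nM
compound 3, `CN1C/C(=C\c2cccs2)C2=NN(C)C(c3cccs3)C2C1`, 89700 nM

These three compounds were tested in a functional assay on cells (Panel renal (Carcinoma cell lines), Homo sapiens) for inhibition; on this read-out higher numbers stand for weaker inhibition of growth and lower numbers for stronger inhibition of growth. Compound 3 has the highest number of the three, meaning the weakest inhibition of growth. Its nearest neighbour is compound 1, whose value lies within the scatter, so the two cannot be told apart. Compound 2 stands furthest away, with a value beyond the scatter and therefore clearly stronger.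

Compound 4, `CN1C/C(=C\c2cccs2)C2=NN(c3ccccc3)C(c3cccs3)C2C1`, differs from compound 3 in one place: phenyl in place of methyl on an amine nitrogen in a ring. Within the data shown here, no pair of measured compounds shows this kind of change, so its effect is unknown. A modest improvement is expected, a 1.8-fold lower number from compound 3 to compound 4 (0.25 log units; within the scatter), because compound 3 sits at 89700 nM. Compound 4 is estimated at 50000 nM, ranging from 15000 nM to 150000 nM.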

Compound 4, concentration for 50% growth inhibition: 65300 nM
Beside the measured number, compound 4's estimate is 1.3-fold (0.12 log units) below it, within the range that was stated.
By their numbers in this assay, from the lowest: compound 2; then compounds 4, 1 and 3 (each within the scatter of the next).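

In this assay, putting phenyl in place of methyl on this amine nitrogen in a ring gives a 1.4-fold lower number from compound 3 to compound 4 (0.14 log units; within the scatter) and so makes no change that can be told from the scatter. At this position, a group of 6 heavy atoms and one aromatic ring therefore reads the same as a single methyl carbon. No measurement shown here offers an explanation for this result.

From the compounds shown here alone, it remains open whether a longer chain, or a phenyl ring carrying an amine or a carboxylic acid, would shift growth inhibition at this nitrogen.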